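The compounds below may be only part of what the source reports. "The series", "measured", "known", "first", "only" and "open" are said of these compounds alone.

Measured in a functional assay on RS4-11 cells (Homo sapiens) for inhibition, read by CCK-8 assay, with a stated time of 72 h; a lower number here means a stronger inhibitor, a higher number a weaker inhibitor:
- compound 1 `CN(C)CCCNc1ccc(S(=O)(=O)NC(=O)c2ccc(N3CCN(CC4=C(c5ccc(C(F)(F)F)cc5)CC(C)(C)CC4)CC3)cc2Oc2cnc3[nH]ccc3c2)cc1[N+](=O)[O-]`: 3.9 nM
- compound 2 `CCN(CC)CCCNc1ccc(S(=O)(=O)NC(=O)c2ccc(N3CCN(CC4=C(c5ccc(C(F)(F)F)cc5)CC(C)(C)CC4)CC3)cc2Oc2cnc3[nH]ccc3c2)cc1[N+](=O)[O-]`: 3 nM

Compound 2 stands level with compound 1. Going by the values given here, the only measured step, a 1.3-fold lower number from compound 1 to compound 2 (0.11 log units; within the scatter), lies within the scatter.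

Next is compound 3 `CN1CCC(CNc2ccc(S(=O)(=O)NC(=O)c3ccc(N4CCN(CC5=C(c6ccc(C(F)(F)F)cc6)CC(C)(C)CC5)CC4)cc3Oc3cnc4[nH]ccc4c3)cc2[N+](=O)[O-])C1`, with the change (1-methylpyrrolidin-3-yl in place of 2-(diethylamino)ethyl on a saturated chain carbon bound to a nitrogen on an aromatic ring). Here 1-methylpyrrolidin-3-yl replaces 2-(diethylamino)ethyl on a saturated chain carbon bound to a nitrogen on an aromatic ring.

Among the compounds with values here, the measured step bears on this only in part: it exchanged dimethylamino for diethylamino, and no compound with the new ring has been measured. That step gives no ground to expect a shift in either direction, so no change beyond the scatter is expected in this assay, though the range is kept wide. The expected change is a 1.3-fold higher number from compound 2 to compound 3 (0.12 log units; within the scatter). The estimate for compound 3 is 4 nM, with an expected range from 1.5 nM to 12 nM.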

Compound 3, half-maximal inhibitory concentration: 8.3 nM
Compound 3: middle estimate off by 2.1-fold (0.32 log units), on the low side, and the stated range covers the measured number.
By their numbers in this assay, from the lowest: compounds 2 and 1 (each within the scatter of the next); then compound 3.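

In this assay, the change from the open 3-(diethylamino)propyl chain to the ring-bearing (1-methylpyrrolidin-3-yl)methyl group gives a 2.8-fold higher number from compound 2 to compound 3 (0.44 log units; beyond the scatter), and the same ring in place of the dimethylamino chain gives a 2.1-fold higher number from compound 1 to compound 3 (0.33 log units; beyond the scatter). The exchange of dimethylamino for diethylamino left the number within the scatter, so this position is not indifferent to every change, although both steps to the ring compound are modest. Nothing at hand accounts for the shift.

Because this change swaps an open chain for a ring and also alters the route to the amine nitrogen, the compounds shown do not separate these two features. A 3-(pyrrolidin-1-yl)propyl group would keep the chain and carry a ring, while a plain alkyl chain without an amine would test whether the amine is needed here.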